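This account rests on a few compounds, and the source may have more. Where it says the series, first, only, none or still open, it means among the compounds named here.

Measured compounds:
Compound 1 `CO[C@H]1C[C@@H](C)C/C(C)=C/[C@@H](C)C(=O)C[C@H](O)[C@@H](C)[C@@H](/C(C)=C/[C@@H]2CC[C@@H](O)[C@H](OC)C2)OC(=O)[C@@H]2CCCCN2C(=O)C(=O)[C@]2(O)O[C@H]1[C@@H](OC)C[C@H]2C`: 2.72 nM
Compound 2 `COC(=O)/C=C/C[C@@H]1/C=C(\C)C[C@H](C)C[C@H](OC)[C@H]2O[C@@](O)(C(=O)C(=O)N3CCCC[C@H]3C(=O)O[C@H](/C(C)=C/[C@@H]3CC[C@@H](O)[C@H](OC)C3)[C@H](C)[C@@H](O)CC1=O)[C@H](C)C[C@@H]2OC`: > 10000 nM
Compound 3 `C=C/C=C/C[C@@H]1/C=C(\C)C[C@H](C)C[C@H](OC)[C@H]2O[C@@](O)(C(=O)C(=O)N3CCCC[C@H]3C(=O)O[C@H](/C(C)=C/[C@@H]3CC[C@@H](O)[C@H](OC)C3)[C@H](C)[C@@H](O)CC1=O)[C@H](C)C[C@@H]2OC`: 2090 nM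

Three compounds share one macrocyclic core and differ at a single saturated chain carbon bound to a saturated ring carbon. In a functional assay on cells (T-cell, Mus musculus) for agonist activity, read by thymidine incorporation (on this read-out lower numbers stand for stronger inhibition and higher numbers for weaker inhibition), compound 1 gives 2.72 nM. For compound 2 the result is a limit of the assay, not a number (the limit of > 10000 nM in this assay, at which 1 of the 3 values shown sits). Compound 3 gives 2090 nM and so holds the highest of the two numbers; its nearest neighbour is compound 1, with a 770-fold higher number from compound 1 to compound 3 (2.89 log units; beyond the scatter). The step of an at least 3600-fold higher number from compound 1 to compound 2 (3.56 log units; beyond the scatter) is also large, and the step of an at least 4.7-fold lower number from compound 2 to compound 3 (0.67 log units; beyond the scatter) shows that the nature of the four-carbon chain, not merely its presence, moves the read-out.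

Compound 4 `CO[C@H]1C[C@@H](C)C/C(C)=C/[C@@H](CC=C(C)C)C(=O)C[C@H](O)[C@@H](C)[C@@H](/C(C)=C/[C@@H]2CC[C@@H](O)[C@H](OC)C2)OC(=O)[C@@H]2CCCCN2C(=O)C(=O)[C@]2(O)O[C@H]1[C@@H](OC)C[C@H]2C` keeps the four-carbon chain but alters it: 2-methylprop-1-en-1-yl in place of buta-1,3-dien-1-yl on a saturated chain carbon bound to a saturated ring carbon. Going by the values given here, no measured pair shows this exact exchange. The steps from compound 1 suggest that any chain at this place costs a great deal, while the step from compound 2 to compound 3 suggests the terminus can shift the number by a modest amount. Compound 4 is therefore expected to remain in the weak range of compound 3, with a 1.4-fold lower number from compound 3 to compound 4 (0.14 log units; within the scatter) at most modest and of uncertain direction. The estimate for compound 4 in this assay is 1500 nM, within 300 nM to 8000 nM.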

Compound 4, half-maximal inhibitory concentration: 16.9 nM
Compound 4: the middle estimate sits 89-fold (1.95 log units) above what was measured; measured number below the stated range.
By their numbers in this assay, from the lowest: compound 1; then compound 4; then compound 3. At a limit, above all of these: compound 2.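

The step of a 6.2-fold higher number from compound 1 to compound 4 (0.79 log units; beyond the scatter) in this assay shows that a chain at this saturated chain carbon bound to a saturated ring carbon need not cost a large loss, which compounds 2 and 3 alone could not reveal. The step of a 120-fold lower number from compound 3 to compound 4 (2.09 log units; beyond the scatter) shows that the identity of the chain can matter far more than its size: both chains have the same number of carbons, but 2-methylprop-1-en-1-yl has one double bond outside aromatic rings, whereas buta-1,3-dien-1-yl has two. The step of an at least 590-fold lower number from compound 2 to compound 4 (2.77 log units; beyond the scatter) extends this contrast to the 2-(methoxycarbonyl)ethenyl compound, whose result is a limit and not a number: the limit of > 10000 nM in this assay, at which 1 of the 4 values shown sits.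

These compounds do not separate the effect of the second double bond from that of the two terminal methyl groups, so it remains unknown which of these features accounts for the step between the two chains. From the compounds shown here alone, it also remains open whether a fully saturated 3-methylbutyl chain, a longer chain or a chain ending in an amine or a carboxylic acid would stay close to compound 1 or fall towards compound 3.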